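Ester variation in a weakly antiproliferative series

A few compounds are considered here, and "the series" means these few. Any claim that something is new, unique, unknown or untested is made for them only; others in the source may bear on it.

Compound 1 `C/C=C1/[C@H](O[C@@H]2O[C@H](CO)[C@@H](O)[C@H](O)[C@H]2O)OC=C(C(=O)OC)[C@H]1CC(=O)O` gives > 15000 nM in a functional assay on SK-BR-3 cells (Homo sapiens) for antiproliferative activity, read by MTT assay, with a stated time of 72 h (on this read-out higher numbers stand for weaker inhibition and lower numbers for stronger inhibition), a limit of the assay.
Compound 2 `C/C=C1/[C@H](O[C@@H]2O[C@H](CO)[C@@H](O)[C@H](O)[C@H]2O)OC=C(C(=O)OC)[C@H]1CC(=O)OCCc1ccccc1` gives 11000 nM.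
Compound 3 `C/C=C1/[C@H](O[C@@H]2O[C@H](CO)[C@@H](O)[C@H](O)[C@H]2O)OC=C(C(=O)OC)[C@H]1CC(=O)OCCc1ccc(OC)cc1` gives > 20000 nM, again a limit.

Compound 3 therefore stands only at a limit (the limit of > 20000 nM in this assay, at which 1 of the 3 values shown sits). Compound 1 also sits at a limit (the limit of > 15000 nM in this assay, at which 1 of the 3 values shown sits). Compound 4 `C/C=C1/[C@H](O[C@@H]2O[C@H](CO)[C@@H](O)[C@H](O)[C@H]2O)OC=C(C(=O)OC)[C@H]1CC(=O)OCCC(C)C` differs from compound 3 by isopropyl in place of 4-methoxyphenyl on a saturated chain carbon, two bonds along the chain from an oxygen next to a carbonyl group. Going by the values given here, no measured step covers this change. The nearest steps are an at least 1.3-fold lower number from compound 1 to compound 2 (0.13 log units; that floor lies within the scatter) and an at least 1.8-fold higher number from compound 2 to compound 3 (0.25 log units; that floor lies within the scatter), both bounded by limits and within the scatter. With every value in this range, no step beyond the scatter is expected in this assay. Compound 4 is expected to give 15000 nM, between 7000 nM and 40000 nM, an expected at least 1.3-fold lower number from compound 3 to compound 4 (0.12 log units; that floor lies within the scatter), and a limit rather than a number is as likely as not.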

Compound 4, half-maximal inhibitory concentration: 9020 nM
Compound 4: middle estimate off by 1.7-fold (0.22 log units), on the high side, within the range that was stated.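

In this assay, going by these compounds alone, isopropyl in place of 4-methoxyphenyl at this position gives an at least 2.2-fold lower number from compound 3 to compound 4 (0.34 log units; beyond the scatter), the first step printed as beyond the scatter. Isopropyl in place of phenyl gives a 1.2-fold lower number from compound 2 to compound 4 (0.09 log units; within the scatter), so an aromatic ring at the chain end is not needed to hold the value of compound 2, while isopentyl in place of hydrogen gives an at least 1.6-fold lower number from compound 1 to compound 4 (0.22 log units; that floor lies within the scatter). Compound 3 stands at a limit, so its step to compound 4 is only a floor: the limit of > 20000 nM in this assay, at which 1 of the 4 values shown sits.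

On these data alone, whether a longer chain or a terminal amine at this position would move the number beyond the scatter remains open.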